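The source may report more compounds than this note shows. Statements on the series, on what has been measured and on what is new or still open speak of the compounds shown alone.

Compound 1 `COc1cc(OC)c2c(c1)C(C(O)c1ccc(OCCOc3ccccc3)cc1)OC2=O`: > 10000 nM
Compound 2 `COc1cc(OC)c2c(c1)C(C(O)c1ccc(OCc3ccccc3)cc1)OC2=O`: > 10000 nM

Both compounds were tested in a functional assay on RAW264.7 cells (Mus musculus) for inhibition, read by Griess assay, with stated times of 1 h and 24 h (on this read-out higher numbers stand for weaker inhibition and lower numbers for stronger inhibition), and neither gave a number. Compound 2 stands at > 10000 nM, which is a limit of the assay. Among the compounds with values here, the series so far offers only (the limit of > 10000 nM in this assay, at which 2 of the 2 values shown sit). Compound 3 `COc1cc(OC)c2c(c1)C(C(O)c1ccc(OCc3ccc(C#N)cc3)cc1)OC2=O` carries cyano in place of hydrogen on an aromatic carbon, para to a large group: cyano in place of hydrogen on an aromatic carbon. Within the data shown here, the one measured step bearing on this is a step that the two limits leave unreadable from compound 1 to compound 2, so it supplies no size to carry over, and no step beyond the scatter is expected in this assay. The estimated step is a number no higher from compound 2 to compound 3 (the limit leaves the size open). For compound 3 the expected value is 10000 nM, with an estimated range of 3000 nM to 30000 nM.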

Compound 3, half-maximal inhibitory concentration: 7360 nM
For compound 3 the middle estimate is 1.4-fold (0.13 log units) above the measured one, within the range that was stated.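

In this assay, within the data shown here, compound 3 gives a number where the earlier compounds gave only a limit, so cyano on this aromatic carbon, para to a large group, is the first change here to yield a readable value. On these data alone, the two steps read an at least 1.3-fold lower number from compound 2 to compound 3 (0.13 log units; that floor lies within the scatter) and an at least 1.3-fold lower number from compound 1 to compound 3 (0.13 log units; that floor lies within the scatter); each is only a floor, and its true size stays open. The other compounds remain unread: the limit of > 10000 nM in this assay, at which 2 of the 3 values shown sit.

What the compounds shown leave open is whether an amine or a carboxylic acid on this carbon would give a lower number than cyano. As far as these compounds go, whether a longer chain carrying cyano would do the same is also open.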